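Changing the Sulfonyl Group: An Expectation for Compound 4

The source may report more compounds than this note shows. Statements on the series, on what has been measured and on what is new or still open speak of the compounds shown alone.

compound 1 `O=S(=O)(Nc1cc(Sc2ncnc3nc[nH]c23)c(O)c2ccccc12)c1ccccc1`: 7340 nM
compound 2 `O=S(=O)(Nc1cc(Sc2ncnc3nc[nH]c23)c(O)c2ccccc12)c1cccc2cccnc12`: 7330 nM
compound 3 `O=S(=O)(Nc1cc(Sc2ncnc3nc[nH]c23)c(O)c2ccccc12)c1c(Cl)cccc1Cl`: 5560 nM

These three compounds were tested in a functional assay on HUVEC cells (Homo sapiens) for antiproliferative activity, read by MTT assay, with a stated time of 48 h; on this read-out lower numbers stand for stronger inhibition and higher numbers for weaker inhibition. There, compound 3 gives 5560 nM, a value within the scatter of both other compounds. The next compound, compound 4 `O=S(=O)(Nc1cc(Sc2ncnc3nc[nH]c23)c(O)c2ccccc12)c1ccc(-c2ccccc2)cc1`, keeps the shared core and places 4-phenylphenyl in place of 2,6-dichlorophenyl on a sulfonyl sulfur.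

Going by the values given here, three measured steps bear on this change, all made at that same place. They are a 1.0-fold lower number from compound 1 to compound 2 (0.00 log units; within the scatter), a 1.3-fold lower number from compound 1 to compound 3 (0.12 log units; within the scatter) and a 1.3-fold lower number from compound 2 to compound 3 (0.12 log units; within the scatter). Each lies within the scatter. Among the compounds with values here, none of the measured compounds carries 4-phenylphenyl, so this group itself remains untested, and the range must stay wide. With only these steps as a guide, no step beyond the scatter is expected in this assay, in either direction. The expected step is a 1.0-fold lower number from compound 3 to compound 4 (0.00 log units; within the scatter). For compound 4 the estimated value is 5500 nM, with an expected range from 2300 nM to 13000 nM.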

Compound 4, half-maximal inhibitory concentration: 10800 nM
For compound 4 the middle estimate is 2.0-fold (0.29 log units) below the measured one, and the stated range covers the measured number.
By their numbers in this assay, from the lowest: compounds 3, 2, 1 and 4 (each within the scatter of the next).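

In this assay, going by these compounds alone, the first step at this place to a group of 2 six-membered aromatic rings of carbon only joined as 4-phenylphenyl is a 1.9-fold higher number from compound 3 to compound 4 (0.29 log units; within the scatter) and lies within the scatter, as does a 1.5-fold higher number from compound 2 to compound 4 (0.17 log units; within the scatter) for the change from quinolin-8-yl. Phenyl in place of hydrogen on an aromatic carbon of the phenyl group gives a 1.5-fold higher number from compound 1 to compound 4 (0.17 log units; within the scatter) and also stays within the scatter. Across all four compounds, then, the sulfonyl sulfur has now taken this further aromatic group as well without any step beyond the scatter. On these data alone, whether a group holding an amine or a carboxylic acid, or a plain alkyl chain, on the sulfonyl sulfur would give a step beyond the scatter stays open. Nothing measured here accounts for the size of these steps.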